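This account rests on a few compounds, and the source may have more. Where it says the series, first, only, none or still open, it means among the compounds named here.

In an ADME assay on HEK293 cells (Homo sapiens) for cytotoxicity, read by resazurin assay, with a stated time of 72 h (on this read-out higher numbers stand for lower toxicity in this test and lower numbers for higher toxicity in this test), three related compounds have been measured, and none has given an exact number. Compound 1 `O=C(O)c1ccc(CCOc2c(F)ccc3nc(C(=O)NCc4ccccc4)[nH]c(=O)c23)cc1` is reported as > 20000 nM, which is a limit of the assay. Compound 2 `Cc1cc(CNC(=O)c2nc3ccc(F)c(OCCc4ccc(C(=O)O)cc4)c3c(=O)[nH]2)ccc1F` is reported as > 20000 nM, again a limit. Compound 3 `CC(C)c1cccc(CNC(=O)c2nc3ccc(F)c(OCCc4ccc(C(=O)O)cc4)c3c(=O)[nH]2)c1` is reported as > 20000 nM, also a limit, so it stands with the other two: the limit of > 20000 nM in this assay, at which 3 of the 3 values shown sit.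

Compound 4 `O=C(O)c1ccc(CCOc2c(F)ccc3nc(C(=O)NCc4cccc(C5CC5)c4)[nH]c(=O)c23)cc1` differs from compound 3 in one place, with cyclopropyl in place of isopropyl on an aromatic carbon, meta to a large group (cyclopropyl in place of isopropyl on an aromatic carbon). The measured steps closest to this change are a step that the two limits leave unreadable from compound 1 to compound 3 and a step that the two limits leave unreadable from compound 2 to compound 3, and the remaining one is a step that the two limits leave unreadable from compound 1 to compound 2. None of them has a readable size, although all three compounds share the same limit. On that basis, no change beyond the usual scatter is expected in this assay, in either direction. The expected size is a step that the limit leaves unreadable from compound 3 to compound 4. For compound 4 the estimate is 25000 nM, within an expected range of 12000 nM to 50000 nM, and a report of only a limit is the likeliest outcome.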

Compound 4, half-maximal cytotoxic concentration: > 20000 nM
Compound 4: no number, only a limit (the forecaster's own chance of this, stated with the estimate: 85%); the middle value lies beyond the limit too.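

In this assay compound 4 gives > 20000 nM, which is a limit and not a number, so its steps from compound 1, compound 2 and compound 3 cannot be read. The compounds shown leave open whether these four differ in toxicity at all, with no exact number shown for any of them.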